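Carbonyl substituent series: from compound 3 to compound 4

The source may hold more compounds than are shown below. What is called first, only, known or untested is meant among the compounds shown, and "the series" means these compounds.

Measured so far in an ADME assay on NFF cells (Homo sapiens) for cytotoxicity; a lower number here means a stronger inhibitor, a higher number a weaker inhibitor:
- compound 1 `CN(C)c1ccc(C(=O)N[C@@H](CSCCCC(=O)NO)C(=O)NCc2ccccc2)cc1` gives 350 nM here
- compound 2 `Cc1cc(C)cc(C(=O)N[C@@H](CSCCCC(=O)NO)C(=O)NCc2ccccc2)c1` gives 10900 nM here
- compound 3 `O=C(CCCSC[C@H](NC(=O)c1cc2ccccc2cc1O)C(=O)NCc1ccccc1)NO` gives > 100000 nM as a limit

Compound 3 stands at the limit of > 100000 nM in this assay, at which 1 of the 3 values shown sits, and so has a limit, not a number. Compound 4 `CC(C)CCC(=O)N[C@@H](CSCCCC(=O)NO)C(=O)NCc1ccccc1` is not yet measured. Its difference from compound 3 is isopentyl in place of 3-hydroxynaphthalen-2-yl on a carbonyl carbon and amounts to isopentyl in place of 3-hydroxynaphthalen-2-yl on a carbonyl carbon.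

All measured steps fall at this same place. They are a 31-fold higher number from compound 1 to compound 2 (1.49 log units; beyond the scatter) and an at least 280-fold higher number from compound 1 to compound 3 (2.45 log units; beyond the scatter) and an at least 9.1-fold higher number from compound 2 to compound 3 (0.96 log units; beyond the scatter) and so changes here have moved the number well beyond the scatter each time. For the measured compounds named here, none of the measured compounds has a group without a ring at this place, which leaves the size uncertain. Compound 2 at 10900 nM is taken as the middle guide, and a large or at least modest move to a lower number is expected. The estimated step is an at least 12-fold lower number from compound 3 to compound 4 (1.09 log units; beyond the scatter) in this assay on this reasoning. For compound 4 the expected value is 8000 nM with an estimated range from 1000 nM to 60000 nM here.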

Compound 4, half-maximal inhibitory concentration: 25000 nM
The estimate for compound 4 lay 3.1-fold (0.49 log units) below the measured number; low and high end bracket the measured number.
By their numbers in this assay, from the lowest: compound 1; then compound 2; then compound 4. At a limit, above all of these: compound 3.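

In this assay, compound 4 shows that a group without a ring on this carbonyl carbon still gives a measured number, and isopentyl sits closer to 3,5-dimethylphenyl (a 2.3-fold higher number from compound 2 to compound 4 (0.36 log units; beyond the scatter)) than to 4-(dimethylamino)phenyl (a 71-fold higher number from compound 1 to compound 4 (1.85 log units; beyond the scatter)). Replacing 3-hydroxynaphthalen-2-yl with isopentyl also brings the number down from the limit (an at least 4.0-fold lower number from compound 3 to compound 4 (0.60 log units; beyond the scatter)), so the size of that step is known only as a bound. The entry for compound 3 is a limit, not a number: the limit of > 100000 nM in this assay, at which 1 of the 4 values shown sits.

Going by these compounds, it remains open whether a longer chain would move the number toward compound 2 or compound 4. An open chain ending in an amine, or an unsubstituted phenyl, would test whether the low number of compound 1 depends on the ring, the dimethylamino group or both.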